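Adding a Methyl Group to a Saturated Ring Carbon

This account rests on a few compounds, and the source may have more. Where it says the series, first, only, none or still open, it means among the compounds named here.

Four compounds share one core and differ in two places. Compound 1 `COc1cc2c(Oc3ccc(NC(=O)c4nn(-c5ccccc5OC(F)(F)F)c(=O)cc4C)cc3F)ccnc2cc1OCCCN1CCCCC1` is the reference point; in a functional assay on MKN-45 cells (Homo sapiens) for inhibition, read by MTT assay, with a stated time of 72 h (a higher number here means a weaker inhibitor, a lower number a stronger inhibitor), compound 1 gives 40 nM. Compound 2 `COc1cc2c(Oc3ccc(NC(=O)c4nn(-c5ccccc5OC(F)(F)F)c(=O)cc4C)cc3F)ccnc2cc1OCCCN1CCC(C)CC1` differs from compound 1 by methyl in place of hydrogen on a saturated ring carbon and in this assay compound 2 gives 70 nM, so the step is a 1.8-fold higher number from compound 1 to compound 2 (0.24 log units; within the scatter). Compound 3 `COc1cc2c(Oc3ccc(NC(=O)c4nn(-c5ccc(Cl)cc5Cl)c(=O)cc4C)cc3F)ccnc2cc1OCCCN1CCCCC1` differs from compound 1 in the other place, by 2,4-dichlorophenyl in place of 2-(trifluoromethoxy)phenyl on an aromatic nitrogen; in this assay compound 3 gives 80 nM, which amounts to a 2.0-fold higher number from compound 1 to compound 3 (0.30 log units; within the scatter). Both steps stay within the usual scatter, so the measurements give no clear sign that either change matters much on its own.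

Compound 4 `COc1cc2c(Oc3ccc(NC(=O)c4nn(-c5ccc(Cl)cc5Cl)c(=O)cc4C)cc3F)ccnc2cc1OCCCN1CCC(C)CC1` has not yet been measured. Among the compounds with values here, it differs from compound 3 by methyl in place of hydrogen on a saturated ring carbon, which is the same change, at the same place, as the one between compound 1 and compound 2. Within the data shown here, the only guide to its effect is that single earlier step. For compound 4 a step of a 1.5-fold higher number from compound 3 to compound 4 (0.18 log units; within the scatter) is expected because the same change on the other core gave a 1.8-fold higher number from compound 1 to compound 2 (0.24 log units; within the scatter), a step that itself lies within the scatter, so only a small movement is expected now. In this assay compound 4 is therefore estimated at 120 nM, with a likely range from 50 nM to 300 nM.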

Compound 4, half-maximal inhibitory concentration: 120 nM
The estimate for compound 4 equals the measured number at the digits printed; the measured number falls inside the stated range.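

Set on the core of compound 3, the change from piperidin-1-yl to 4-methylpiperidin-1-yl gives a 1.5-fold higher number from compound 3 to compound 4 (0.18 log units; within the scatter) in this assay, and this step agrees with the earlier one within the scatter:  the same change on two cores in this assay, a 1.8-fold higher number (0.24 log units; within the scatter) from compound 1 to compound 2 and a 1.5-fold higher number (0.18 log units; within the scatter) from compound 3 to compound 4, 1.2-fold (0.07 log units) apart, within the scatter of two such steps

The other change, made with the 4-methylpiperidin-1-yl group present, gives a 1.7-fold higher number from compound 2 to compound 4 (0.23 log units; within the scatter) and likewise agrees with its earlier counterpart within the scatter:  the same change on two cores in this assay, a 2.0-fold higher number (0.30 log units; within the scatter) from compound 1 to compound 3 and a 1.7-fold higher number (0.23 log units; within the scatter) from compound 2 to compound 4, 1.2-fold (0.07 log units) apart, within the scatter of two such steps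

Together, these four compounds show that the methyl step looks much the same on both cores, and they give no sign that either change alters what the other does; however, each step is itself within the scatter, so they do not show that the methyl has any real effect, and two cores cannot show that the agreement would hold on a third.

Going by these compounds, it remains open what would happen with a different group on that saturated ring carbon, such as an ethyl or a hydroxyl, or with a morpholin-4-yl group in place of the piperidin-1-yl. Also open, on these data alone, is whether the methyl step would stay this small with another group on the aromatic nitrogen, such as an unsubstituted phenyl.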